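Swapping the Benzyl Substituent on a Shared Core

This account rests on a few compounds, and the source may have more. Where it says the series, first, only, none or still open, it means among the compounds named here.

Compound 1 `Nc1cc(N)c2nc(-c3ccccc3)c(NCc3ccc(Cl)c(Cl)c3)nc2c1` was tested in a functional assay on UACC-62 cells (Homo sapiens) for inhibition, read by sulforhodamine B assay, with a stated time of 48 h (a higher number here means a weaker inhibitor of growth, a lower number a stronger inhibitor of growth), where compound 1 gives 14100 nM. Compound 2 `CCOC(=O)[C@H](CCC(=O)O)NC(=O)c1ccc(Sc2nc3cc(N)cc(N)c3nc2-c2ccccc2)cc1` gives 17800 nM in this assay; the two numbers lie within the usual scatter of each other, so compound 1 has the lower of the two numbers without standing apart from compound 2. Compound 3 `COc1ccc(CNc2nc3cc(N)cc(N)c3nc2-c2ccccc2)cc1` differs from compound 1 in one place: 4-methoxyphenyl in place of 3,4-dichlorophenyl on a saturated chain carbon bound to a nitrogen on an aromatic ring. Among the compounds with values here, no measured pair shows this change, so only a small step is expected, a 1.3-fold higher number from compound 1 to compound 3 (0.11 log units; within the scatter), toward a higher number if anything and within the scatter. Compound 3 is expected to give 18000 nM, between 6000 nM and 55000 nM.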

Compound 3, concentration for 50% growth inhibition: 14800 nM
Beside the measured number, compound 3's estimate is 1.2-fold (0.09 log units) above it; low and high end bracket the measured number.
By their numbers in this assay, from the lowest: compounds 1, 3 and 2 (each within the scatter of the next).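

Putting 4-methoxyphenyl in place of 3,4-dichlorophenyl on a saturated chain carbon bound to a nitrogen on an aromatic ring gives a 1.0-fold higher number from compound 1 to compound 3 (0.02 log units; within the scatter) in this assay, a step within the scatter. At this position, then, the two benzyl substituents, one carrying chlorine and the other oxygen, cannot be told apart in this assay. No supporting measurement bears on this result.

From the compounds shown here alone, whether an amine or a carboxylic acid on this ring would give a different number remains open. So does the effect of a longer chain joining the ring to the shared core.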